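This account rests on a few compounds, and the source may have more. Where it says the series, first, only, none or still open, it means among the compounds named here.

Measured so far:
compound 1 `O=C(N/N=C/c1ccc(F)cc1)Nc1cc2c(Nc3ccc(F)c(Cl)c3)ncnc2cc1O[C@H]1CCOC1` — 35100 nM
compound 2 `O=C(N/N=C/c1cccc(Br)c1)Nc1cc2c(Nc3ccc(F)c(Cl)c3)ncnc2cc1O[C@H]1CCOC1` — 10700 nM
compound 3 `O=C(N/N=C/c1ccc(F)cc1Cl)Nc1cc2c(Nc3ccc(F)c(Cl)c3)ncnc2cc1O[C@H]1CCOC1` — 27200 nM

In a functional assay on A549 cells (Homo sapiens) for cytotoxicity, read by MTT assay, with a stated time of 72 h (a higher number here means a weaker inhibitor, a lower number a stronger inhibitor), compound 1 gives the highest number of the three, with compound 3 nearest a 1.3-fold lower number from compound 1 to compound 3 (0.11 log units; within the scatter) and compound 2 furthest a 3.3-fold lower number from compound 1 to compound 2 (0.52 log units; beyond the scatter). Compound 4 `COc1ccc(/C=N/NC(=O)Nc2cc3c(Nc4ccc(F)c(Cl)c4)ncnc3cc2O[C@H]2CCOC2)cc1` is not yet measured. It differs from compound 1 in one place: methoxy in place of fluoro on an aromatic carbon. Among the measured compounds shown here, no measured step swaps exactly this group. The steps that touch the same ring change it elsewhere: a 1.3-fold lower number from compound 1 to compound 3 (0.11 log units; within the scatter) adds a group and stays within the scatter, while a 3.3-fold lower number from compound 1 to compound 2 (0.52 log units; beyond the scatter) moves the group and changes the ring and gives a modest gain, and a 2.5-fold higher number from compound 2 to compound 3 (0.41 log units; beyond the scatter) moves part of the way back. Two of three changes to this ring therefore left the number close to where it started, and one gave a modest change. For compound 4 a step within the scatter, or at most a modest one in either direction, is expected a 1.2-fold lower number from compound 1 to compound 4 (0.07 log units; within the scatter). The estimate for compound 4 is 30000 nM, with a range from 12000 nM to 70000 nM.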

Compound 4, half-maximal inhibitory concentration: 33100 nM
Compound 4: middle estimate off by 1.1-fold (0.04 log units), on the low side, and the stated range covers the measured number.
By their numbers in this assay, from the lowest: compound 2; then compounds 3, 4 and 1 (each within the scatter of the next).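

In this assay, among the compounds shown here, replacing fluoro with methoxy on the aromatic carbon para to a large group, the direct swap at this position that the earlier compounds lacked, leaves the number in place (a 1.1-fold lower number from compound 1 to compound 4 (0.03 log units; within the scatter)). Compound 4 also stays level with the chlorine-bearing ring of compound 3 (a 1.2-fold higher number from compound 3 to compound 4 (0.09 log units; within the scatter)), while compound 2 remains apart from it (a 3.1-fold higher number from compound 2 to compound 4 (0.49 log units; beyond the scatter)), so among these four only the 3-bromophenyl compound stands out from the rest. Nothing available here accounts for why these two groups give matching numbers.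

Still open, from the compounds shown here alone, is whether a group of another kind at this position, such as an amine, a carboxylic acid or a longer chain, would shift the number. Also open, going by these compounds, is whether the result for compound 2 belongs to the bromo group itself or to where it sits on the ring.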